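This account rests on a few compounds, and the source may have more. Where it says the series, first, only, none or still open, it means among the compounds named here.

Compound 1 `O=C([C@H]1Cc2cc(Cl)cc(-c3ccnc4ccsc34)c2O1)N1CCNCC1` was measured in an assay on isolated protein for inhibition of ubiquitin carboxyl-terminal hydrolase 47 (Homo sapiens) (on this read-out higher numbers stand for weaker inhibition and lower numbers for stronger inhibition), where compound 1 gives > 40000 nM, a limit of the assay rather than a number.
Compound 2 `O=C([C@H]1Cc2cc(Cl)cc(-c3ccnc4cc(C5(O)COC5)sc34)c2O1)N1CCNCC1` was also measured, and in this assay compound 2 gives > 40000 nM, again a limit.
Compound 3 `O=C([C@H]1Cc2cc(Cl)cc(-c3ccnc4cc(C(O)(CO)CCl)sc34)c2O1)N1CCNCC1` completes the set; in this assay compound 3 gives > 40000 nM, once more a limit.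

Compound 3 therefore stands nowhere in particular on the numbers shown: its result is only a limit, and so are the other two, all three sitting at the limit of > 40000 nM in this assay, at which 3 of the 3 values shown sit. The steps among the measured compounds tell nothing about size: the step that the two limits leave unreadable from compound 1 to compound 2, the step that the two limits leave unreadable from compound 1 to compound 3 and the step that the two limits leave unreadable from compound 2 to compound 3 are each unreadable because both ends are limits.

Compound 4 `Cc1cc2nccc(-c3cc(Cl)cc4c3O[C@@H](C(=O)N3CCNCC3)C4)c2s1` differs from compound 3 by methyl in place of 1-(chloromethyl)-1,2-dihydroxyethyl on an aromatic carbon. Among the compounds with values here, none of the measured steps gives a readable size to lean on; what they share is that every variation at this aromatic carbon so far has stayed at the limit. The step from compound 3 to compound 4 is therefore expected to be a number no higher from compound 3 to compound 4 (the limit leaves the size open), that is, not readable beyond the limit. For compound 4 the estimate in this assay is 40000 nM, with a range from 10000 nM to 100000 nM, and most likely only a limit will again be reported.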

Compound 4, half-maximal inhibitory concentration: > 80000 nM
Compound 4 gave a limit, no number; the forecaster's own chance of this, stated with the estimate: 85%; at least 2.0-fold (0.30 log units) between middle value and limit.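

The steps from compound 1, compound 2 and compound 3 to compound 4 cannot be read: compound 4, like the other three, gives only a limit in this assay. The compounds shown leave open whether any group at this aromatic carbon gives a measurable inhibition.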